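Swapping Methoxy for Chloro on a Cell Assay Compound

This account rests on a few compounds, and the source may have more. Where it says the series, first, only, none or still open, it means among the compounds named here.

Compound 2 `COc1ccc(NC(=O)Oc2cc(=O)n(CCCO)c3c2CC(C/C=C(\C)CCC=C(C)C)C(C)(C)C3)cc1` is the starting point in a functional assay on PANC-1 cells (Homo sapiens) for inhibition, read by MTT assay, with a stated time of 24 h, tested at 10 uM; on this read-out lower numbers stand for less inhibition and higher numbers for more inhibition at the one concentration tested (going by the name of the read-out): compound 2 gives 0%, meaning the cells grew as if untreated. Its close relative compound 1 `COc1ccc(NC(=O)Oc2cc(=O)n(CCCO)c3c2CC(CC=C(C)C)C(C)(C)C3)cc1` is no different; in this assay compound 1 gives 0%, and the step of no change at the digits printed from compound 1 to compound 2 (within the scatter) shows that attaching a 3-methylbut-2-en-1-yl chain in place of hydrogen left the read-out untouched. Compound 3 `CC(C)=CCC/C(C)=C/CC1Cc2c(OC(=O)Nc3ccc(Cl)cc3)cc(=O)n(CCCO)c2CC1(C)C` keeps everything of compound 2 except one group on an aromatic carbon of a six-membered aromatic ring of carbon only: chloro in place of methoxy on an aromatic carbon. Going by the values given here, no measured step touches that ring, so there is no direct guide. Among the compounds with values here, with both measured compounds at zero and the one step seen flat, the step of no change at the digits printed from compound 2 to compound 3 (within the scatter) is expected to stay within the scatter. Compound 3 is therefore estimated to give 0% in this assay, with a range from -10% to 15%.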

Compound 3, a percentage reported as inhibition, at one concentration (the size of the read-out at that concentration, not a potency): 4.3%
The estimate for compound 3 lay 4.3 percentage points below the measured number; the range from low to high includes it.
By their numbers in this assay, from the lowest: compounds 1, 2 and 3 (each within the scatter of the next).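

Putting chloro in place of methoxy on the aromatic ring, para to a large group, gives in this assay a number 4.3 percentage points higher from compound 2 to compound 3 (within the scatter). Going by these compounds alone, the earlier step changed only the chain, so this is the first reading for the ring: exchanging the 4-methoxyphenyl for the 4-chlorophenyl, with one chlorine atom replacing a carbon and an oxygen, does not move the read-out beyond the usual scatter. No supporting measurement is available to explain why these two groups read alike.

On these data alone, whether an amine or a carboxylic acid at the same ring position would give a clearer read-out remains open. So does whether any change on this ring can produce inhibition that stands clearly beyond the scatter.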